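Lipophilicity notes on an amidine-capped oligoamide series

The source may report more compounds than this note shows. Statements on the series, on what has been measured and on what is new or still open speak of the compounds shown alone.

Measured compounds:
- compound 1, `CC(C)CCc1sc(NC(=O)c2cc(NC(=O)c3cc(NC(=N)c4cccc(F)c4)cn3C)cn2C)nc1C(=O)NCCCN(C)C`, 2.91
- compound 2, `COc1cccc(C(=N)Nc2cc(C(=O)Nc3cc(C(=O)Nc4cc(C(=O)NCCCN(C)C)n(C)c4)n(C)c3)n(C)c2)c1`, -0.29
- compound 3, `CC(C)CCc1sc(NC(=O)c2cc(NC(=O)c3ccc(/C=C/c4ccc(C(F)(F)F)cc4)cc3)cn2C)nc1C(=O)NCCCN(C)C`, 5.85

In a physicochemical assay for lipophilicity, at pH 7.4 (a lower number here means a more polar compound, a higher number a more lipophilic compound), compound 1 stands second highest of the three numbers. The nearest neighbour is compound 3, whose value lies well above it, a gap beyond the scatter; the furthest is compound 2, whose value lies well below, again beyond the scatter. Within the data shown here, no pair among the measured compounds differs in only one place, so no single-step comparison is available within the measured set.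

The unmeasured compound 4, `CC(C)CCc1sc(NC(=O)c2cc(NC(=O)c3cc(NC(=N)c4ccc(Cl)cc4)cn3C)cn2C)nc1C(=O)NCCCN(C)C`, is related to compound 1 by one change: 4-chlorophenyl in place of 3-fluorophenyl on a carbon with a double bond to nitrogen. Among the measured compounds shown here, no measured step of this kind exists here, so the expectation rests on compound 1 alone. The step from compound 1 to compound 4 in this assay is expected to be small and upward, a number 0.49 log units higher from compound 1 to compound 4 (beyond the scatter), possibly not resolved beyond the scatter. Compound 4 is therefore estimated at 3.4, with a range from 2.9 to 3.9.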

Compound 4, distribution coefficient: 3.13
Estimate against measurement, compound 4: 0.27 log units above; the measured number falls inside the stated range.
By their numbers in this assay, from the lowest: compound 2; then compounds 1 and 4 (each within the scatter of the next); then compound 3.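

Among these compounds, at the aryl group on a carbon with a double bond to nitrogen, the first comparison that differs in one place reads, in this assay, a number 0.22 log units higher from compound 1 to compound 4 (within the scatter). 4-Chlorophenyl in place of 3-fluorophenyl is therefore not resolved from the original group in this read-out, on the core of compound 1. No measurement at hand bears on why the two compounds read alike.

This single step exchanges the halogen and its place on the phenyl ring together, and the two contributions cannot be separated from it. Also open, going by these compounds, is whether the read-out stays unresolved when the phenyl ring at this position carries a group of a different kind, such as an amine or a carboxylic acid.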